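Replacing the dicyclopropylmethyl group on the amino nitrogen

This account rests on a few compounds, and the source may have more. Where it says the series, first, only, none or still open, it means among the compounds named here.

Of the compounds shown here, two sharing one core have been measured so far. Compound 1 `CCc1nc(NC(CC)CC)cnc1-c1ccc(Cl)cc1Cl` gives 545 nM in an assay on IMR-32 cells for displacement of a labelled ligand from corticotropin-releasing factor receptor 1 (Homo sapiens), read by scintillation counting, with a stated time of 2 h; on this read-out lower numbers stand for stronger inhibition and higher numbers for weaker inhibition. Compound 2 `CCc1nc(-c2ccc(Cl)cc2Cl)c(CC)nc1NC(C1CC1)C1CC1` gives 3.7 nM in this assay, the lower of the two numbers by a margin well beyond the scatter, so compound 2 stands as the more potent of the pair on the numbers shown.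

Compound 3 `CCc1nc(-c2ccc(Cl)cc2Cl)c(CC)nc1NC(C)CN(C)C` has not yet been measured. It differs from compound 2 in one place: 1-((dimethylamino)methyl)ethyl in place of dicyclopropylmethyl on a nitrogen on an aromatic ring. For the measured compounds named here, no pair of measured compounds differs in this position, so the size of such a step is not known from the data at hand.

The author's expectation is a loss of potency in this assay for compound 3, with the number rising from the value of compound 2 by a step that is expected to be clearly beyond the scatter, a 32-fold higher number from compound 2 to compound 3 (1.51 log units; beyond the scatter). On that basis compound 3 is estimated at 120 nM in this assay, with a likely range from 20 nM to 700 nM.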

Compound 3, inhibition constant: 489 nM
The estimate for compound 3 lay 4.1-fold (0.61 log units) below the measured number, and the stated range covers the measured number.
By their numbers in this assay, from the lowest: compound 2; then compounds 3 and 1 (each within the scatter of the next).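

In this assay, the exchange of dicyclopropylmethyl for 1-((dimethylamino)methyl)ethyl on the nitrogen on an aromatic ring gives a 130-fold higher number from compound 2 to compound 3 (2.12 log units; beyond the scatter), the first step read at this position, and it shows that the number depends strongly on the group held there. The change is not a single alteration: both three-membered carbon rings leave, and a ring-free chain enters that carries a nitrogen and a hydrogen-bond acceptor, so the two compounds alone do not separate these differences. No measurement offered here bears on why the number rises.

As far as these compounds go, it remains open whether the step follows the removal of the cyclopropyl rings or the arrival of the dimethylamino group, a question that a plain sec-butyl group or a 1-methoxypropan-2-yl group on the same nitrogen would help to divide. Also unsettled is how a cyclic amine such as pyrrolidine or morpholine, or a longer chain ending in dimethylamino, would fare at this position on the shared core.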